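Swapping a chlorophenyl for a furan on a thiosemicarbazone

A few compounds are considered here, and "the series" means these few. Any claim that something is new, unique, unknown or untested is made for them only; others in the source may bear on it.

Compound 1 (`CC1=CC[C@H](C(C)(C)NC(=S)NN)CC1`) is the parent thiosemicarbazide. In a functional assay on K562 cells (Homo sapiens) for inhibition, read by sulforhodamine B assay, with a stated time of 48 h (on this read-out higher numbers stand for weaker inhibition of growth and lower numbers for stronger inhibition of growth), compound 1 reaches only a limit, > 100000 nM, so no number is known for it. Attaching a 2-chlorophenyl group through a carbon double-bonded to nitrogen gives compound 2 (`CC1=CC[C@H](C(C)(C)NC(=S)N/N=C/c2ccccc2Cl)CC1`), which in this assay gives 66200 nM. Within the data shown here, that is the only real number in the set, since the other value sits at the limit of > 100000 nM in this assay, at which 1 of the 2 values shown sits, so compound 2 stands alone and no measured step can be drawn.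

Compound 3 (`CC1=CC[C@H](C(C)(C)NC(=S)N/N=C/c2ccco2)CC1`) keeps the whole core and changes only the aromatic group: furan-2-yl in place of 2-chlorophenyl on a carbon with a double bond to nitrogen. Among the measured compounds shown here, with no measured step of this kind to lean on, the expected change from compound 2 to compound 3 is small, about a 1.2-fold higher number from compound 2 to compound 3 (0.08 log units; within the scatter), and a loss toward the limit is as plausible as a gain. Compound 3 is therefore estimated at 80000 nM, within a range of 30000 nM to 200000 nM.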

Compound 3, concentration for total growth inhibition: > 100000 nM
Compound 3: a limit, no number; the forecaster's own chance of this, stated with the estimate: 40%; middle value at least 1.2-fold (0.09 log units) from the limit.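

The furan-2-yl compound gives no number in this assay, only a limit, so the group on this carbon can move a compound from a readable value to the limit. The change to furan-2-yl in place of 2-chlorophenyl gives an at least 1.5-fold higher number from compound 2 to compound 3 (0.17 log units; that floor lies within the scatter); this is only a floor, so the true gap could be small or much larger, and the step from compound 1 to compound 3 cannot be read at all. Among these compounds, compound 2 is still the only compound with a real number, and most of the set now sits at the limit: the limit of > 100000 nM in this assay, at which 2 of the 3 values shown sit.

Going by these compounds, what remains open is whether the chlorine itself matters, which a plain phenyl group on this carbon would test. Also open, on these data alone, is whether a thiophen-2-yl group would behave like furan-2-yl or give a readable value.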